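The source may report more compounds than this note shows. Statements on the series, on what has been measured and on what is new or still open speak of the compounds shown alone.

Series notes, cytotoxicity on a melanoma line.

Of the compounds shown here, two have numbers so far. Compound 1 `ClCc1ccc(Cn2cnc3c(Cl)ncnc32)cc1` carries a chloromethyl group on the benzyl ring and a single chloro on the fused core; in a functional assay on UACC-62 cells (Homo sapiens) for cytotoxicity, read by sulforhodamine B assay, with a stated time of 48 h (a higher number here means that more compound is tolerated, a lower number that less compound is tolerated), compound 1 gives 9450 nM. Compound 2 `ClCc1ccccc1Cn1cnc2c(Cl)nc(Cl)nc21` carries the chloromethyl group at the other position of the benzyl ring and two chloro groups on the core; in this assay compound 2 gives 5240 nM. Compound 2 stands at the lowest of the two numbers, its nearest neighbour being compound 1, whose number is higher by an amount that falls within the scatter, so no ordering between the two can be claimed.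

Compound 3 `ClCc1ccccc1Cn1cnc2c(Cl)ncnc21` has not yet been measured in this assay. It differs from compound 2 in one place: hydrogen in place of chloro on an aromatic carbon. Among the compounds with values here, no step between measured compounds is available to calibrate this change. The expectation is a step in this assay from compound 2 to compound 3 of a 1.5-fold higher number from compound 2 to compound 3 (0.18 log units; within the scatter), upward if anything, but not beyond the scatter. Compound 3 is estimated at 8000 nM, with a range from 3000 nM to 25000 nM.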

Compound 3, concentration lethal to 50% of the cells: 28200 nM
For compound 3 the middle estimate is 3.5-fold (0.55 log units) below the measured one; measured number above the stated range.
By their numbers in this assay, from the lowest: compounds 2 and 1 (each within the scatter of the next); then compound 3.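

Within the data shown here, the chloro group on the aromatic carbon between two ring nitrogen atoms counts in this assay: hydrogen in its place gives a 5.4-fold higher number from compound 2 to compound 3 (0.73 log units; beyond the scatter), the first step that can be read and one that lies beyond the scatter. The change removes a single chlorine and leaves the chloromethyl group and the other chloro group untouched, so this one position alone is enough to separate two compounds, though the finding rests on a single pair with the chloromethyl group placed as in compound 2. No evidence bears on what lies behind the step.

From the compounds shown here alone, it remains open whether the same exchange gives a step of similar size with the chloromethyl group at the other position of the benzyl ring, as in compound 1, and a compound with two chloro groups on the core and that arrangement would answer this. Also open, going by these compounds, is how other groups on this carbon, such as an amine, a methoxy group or a fluoro group, would stand against chloro and hydrogen in this assay.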